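A few compounds are considered here, and "the series" means these few. Any claim that something is new, unique, unknown or untested is made for them only; others in the source may bear on it.

Measured so far in a functional assay on HeLa cells (Homo sapiens) for cytotoxicity, read by MTT assay, with a stated time of 2 days, tested at 1 uM; on this read-out higher numbers stand for a weaker effect at the one concentration tested and lower numbers for a stronger effect:
compound 1 `CC(=O)c1cc(-c2ccccc2)cc2cc(-c3ccccc3)[nH]c12` gives 65.8%;
compound 2 `CC(=O)c1cc(-c2ccc(F)cc2)cc2cc(-c3ccccc3)[nH]c12` gives 82.7%.

Among these two numbers compound 1 stands lowest in this assay. Among the measured compounds shown here, the one measured step is a number 16.9 percentage points higher from compound 1 to compound 2 (beyond the scatter). Compound 3 `CC(=O)c1cc(-c2ccccc2)cc2cc(-c3ccc(F)cc3)[nH]c12` differs from compound 1 by fluoro in place of hydrogen on an aromatic carbon, the same kind of change as in that step but on the other phenyl of the shared core. Since compound 2 showed a number 16.9 percentage points higher from compound 1 to compound 2 (beyond the scatter), a step of similar direction is expected for compound 3, namely a number 10.2 percentage points higher from compound 1 to compound 3 (beyond the scatter). Compound 3 is therefore estimated at 76%, with a range from 60% to 92%.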

Compound 3, a percentage reported as activity, at one concentration (the size of the read-out at that concentration, not a potency): 85.1%
The estimate for compound 3 lay 9.1 percentage points below the measured number; the range from low to high includes it.
By their numbers in this assay, from the lowest: compound 1; then compounds 2 and 3 (each within the scatter of the next).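

In this assay, the change from phenyl to 4-fluorophenyl on the other phenyl of the shared core gives a number 19.3 percentage points higher from compound 1 to compound 3 (beyond the scatter). This runs in the same direction as a number 16.9 percentage points higher from compound 1 to compound 2 (beyond the scatter), so on both phenyls the fluoro goes with a weaker effect at the one concentration tested, and compound 1 keeps the lowest number of the three. Nothing available explains this shift. Open, going by these compounds, is whether a methoxy group or an amine at the same place would follow the fluoro in direction.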